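A few compounds are considered here, and "the series" means these few. Any claim that something is new, unique, unknown or untested is made for them only; others in the source may bear on it.

Notes on the series. Compound 1 `CNC(=O)c1cc(Oc2ccc(NC(=O)c3nn(-c4ccccc4C(F)(F)F)c(=O)cc3C)cc2F)ccn1` gives in a functional assay on HepG2 cells (Homo sapiens) for cytotoxicity, read by MTT assay, with a stated time of 72 h (on this read-out lower numbers stand for stronger inhibition and higher numbers for weaker inhibition), only the limit > 40000 nM and no number. Compound 2 `Cc1cc(=O)n(-c2ccccc2C(F)(F)F)nc1C(=O)Nc1ccc(Oc2ncnc3ccsc23)cc1` gives 9230 nM in this assay, and compound 3 `Cc1ccc(-n2nc(C(=O)Nc3ccc(Oc4ncnc5ccsc45)cc3)c(C)cc2=O)c(C)c1` gives 17900 nM. Among the compounds with values here, the single step measured in one place, a 1.9-fold higher number from compound 2 to compound 3 (0.29 log units; within the scatter), stays within the scatter. Compound 2 therefore holds the lowest of the two numbers, with compound 3 within the scatter of it, while one further entry is a limit. Compound 4 `Cc1cc(=O)n(-c2ccccc2C(F)(F)F)nc1C(=O)Nc1ccc(Oc2ncnc3ccsc23)c(F)c1` differs from compound 2 by fluoro in place of hydrogen on an aromatic carbon. Within the data shown here, no measured step alters this ring; the only measured step, a 1.9-fold higher number from compound 2 to compound 3 (0.29 log units; within the scatter), touches the other aromatic ring and lies within the scatter, so it gives no direction here. Among the measured compounds shown here, compound 1 carries the same fluoro on that ring together with a different aryl ether, and it sits at the limit (the limit of > 40000 nM in this assay, at which 1 of the 3 values shown sits); with two changes at once no single step can be drawn from it. The expected step is a 1.6-fold higher number from compound 2 to compound 4 (0.21 log units; within the scatter), within the scatter. For compound 4 in this assay the estimate is 15000 nM, with a range from 5000 nM to 40000 nM.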

Compound 4, half-maximal inhibitory concentration: 9380 nM
Compound 4: the middle estimate sits 1.6-fold (0.20 log units) above what was measured, and the stated range covers the measured number.
By their numbers in this assay, from the lowest: compounds 2, 4 and 3 (each within the scatter of the next). At a limit, above all of these: compound 1.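

On the six-membered aromatic ring of carbon only, fluoro in place of hydrogen, ortho to a large group and meta to a large group, gives no difference beyond the scatter in this assay: a 1.0-fold higher number from compound 2 to compound 4 (0.01 log units; within the scatter). With that fluoro present in both compounds, the group on the oxygen on an aromatic ring gives a step beyond the scatter, an at least 4.2-fold lower number from compound 1 to compound 4 (0.62 log units; beyond the scatter), so the fluoro alone does not set the reading of compound 1. Compound 1 still gives a limit and no number, so this step has only a lower bound: the limit of > 40000 nM in this assay, at which 1 of the 4 values shown sits.

From the compounds shown here alone, whether chloro, methoxy or an amine in place of the same hydrogen would give a step beyond the scatter stays open. Also open, going by these compounds, is whether fluoro on this ring reads the same alongside the 2,4-dimethylphenyl group of compound 3.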